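From compound 3 to compound 4: hydroxy to dimethylamino

The source may hold more compounds than are shown below. What is called first, only, known or untested is meant among the compounds shown, and "the series" means these compounds.

Compound 1, `CN(C)c1ccc(/C=C(/SCc2ccc(F)cc2)C(=O)c2ccc(Br)cc2)cc1`: 50000 nM
Compound 2, `CN(C)c1ccc(/C=C(/Sc2ccc(Br)cc2)C(=O)c2ccc(Cl)cc2)cc1`: > 100000 nM
Compound 3, `O=C(/C(=C\c1ccc(O)cc1)SCc1ccc(F)cc1)c1ccc(Cl)cc1`: 25000 nM

Of the compounds shown here, three have been measured in a functional assay on DU-145 cells (Homo sapiens) for inhibition, read by trypan blue exclusion, with a stated time of 96 h; a higher number here means a weaker inhibitor of growth, a lower number a stronger inhibitor of growth. Compound 3 gives 25000 nM, the lower of the two numbers reported. Compound 1, the nearest to it, gives 50000 nM, and the gap between compound 3 and compound 1 lies within the scatter of the method, so the two cannot be told apart. The value for compound 2 is a limit rather than a number, since it sits at the limit of > 100000 nM in this assay, at which 1 of the 3 values shown sits.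

Compound 4, `CN(C)c1ccc(/C=C(/SCc2ccc(F)cc2)C(=O)c2ccc(Cl)cc2)cc1`, has not yet been measured in this assay. It differs from compound 3 in one place, (dimethylamino in place of hydroxy on an aromatic carbon). Among the measured compounds shown here, no pair of measured compounds differs in exactly this way, so the size of the step is not known from a measurement. Compound 1, which carries the dimethylamino group, and compound 3, which carries the hydroxy group, give values that are within the scatter of each other. On that basis, for compound 4 the expected step from compound 3 is small, a 2.0-fold higher number from compound 3 to compound 4 (0.30 log units; within the scatter), and no direction beyond the scatter is expected. Compound 4 is therefore estimated at 50000 nM, with a range from 20000 nM to 120000 nM.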

Compound 4, concentration for 50% growth inhibition: 50000 nM
Estimate against measurement, compound 4: no gap at the digits printed; low and high end bracket the measured number.
By their numbers in this assay, from the lowest: compounds 3, 1 and 4 (each within the scatter of the next). At a limit, above all of these: compound 2.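

In this assay, the change from 4-hydroxyphenyl to 4-(dimethylamino)phenyl now has a directly measured step, a 2.0-fold higher number from compound 3 to compound 4 (0.30 log units; within the scatter), so this swap on an aromatic carbon, para to a large group, cannot be told apart from no change while the rest of the molecule stays the same. The step for chloro in place of bromo, no change at the digits printed from compound 1 to compound 4 (within the scatter), shows that this exchange of halogens likewise leaves the two compounds indistinguishable in this assay. Compound 2 stands at a limit rather than a number, so 4-fluorobenzyl in place of 4-bromophenyl on the sulfur can be read only as a floor, an at least 2.0-fold lower number from compound 2 to compound 4 (0.30 log units; that floor lies within the scatter), which leaves the true size of that step unknown: the limit of > 100000 nM in this assay, at which 1 of the 4 values shown sits.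

As far as these compounds go, it remains open whether any group at the hydroxy position, such as a methoxy group, a primary amine or a carboxylic acid, would shift the number beyond the scatter. From the compounds shown here alone, it is equally open how a longer chain between the sulfur and its aromatic ring, or a fluoro or methoxy group in place of the chloro, would read in this assay.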